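This account rests on a few compounds, and the source may have more. Where it says the series, first, only, none or still open, it means among the compounds named here.

Of the compounds shown here, two with the same core have been measured in a functional assay on Jurkat cells (Homo sapiens); on this read-out lower numbers stand for stronger inhibition and higher numbers for weaker inhibition. Compound 1 (`CC(C)[C@H](NC(=O)COc1cccc2ccccc12)C(=O)N[C@@H](CC(=O)O)C(=O)COc1ccc(F)c(F)c1F`), which carries a 2,3,4-trifluorophenyl group on the oxygen, gives 35800 nM. Compound 2 (`CC(C)[C@H](NC(=O)COc1cccc2ccccc12)C(=O)N[C@@H](CC(=O)O)C(=O)COc1cc(F)cc(F)c1F`), which carries a 2,3,5-trifluorophenyl group there, gives 30000 nM. Among the compounds with values here, the one measured step is a 1.2-fold lower number from compound 1 to compound 2 (0.08 log units; within the scatter), so compound 2 stands level with compound 1 and the two cannot be ranked.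

Compound 3 (`CC(C)[C@H](NC(=O)COc1cccc2ccccc12)C(=O)N[C@@H](CC(=O)O)C(=O)COc1c(F)c(F)cc(F)c1F`) differs from compound 2 in one place: fluoro in place of hydrogen on an aromatic carbon. Fluoro takes the place of hydrogen on an aromatic carbon, which turns the 2,3,5-trifluorophenyl group into a 2,3,5,6-tetrafluorophenyl group. Within the data shown here, no measured step adds a fluoro, so the evidence is indirect. The closest guide is the change of fluoro pattern from compound 1 to compound 2, and that step, a 1.2-fold lower number from compound 1 to compound 2 (0.08 log units; within the scatter), stayed small. As far as these compounds go, no step beyond the scatter is therefore expected in this assay, though the direction remains open. The expected step is a 1.4-fold lower number from compound 2 to compound 3 (0.13 log units; within the scatter). For compound 3 the estimated value is 22000 nM, with an expected range of 7000 nM to 60000 nM.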

Compound 3, half-maximal inhibitory concentration: 4500 nM
The estimate for compound 3 lay 4.9-fold (0.69 log units) above the measured number, outside the stated range (below it).
By their numbers in this assay, from the lowest: compound 3; then compounds 2 and 1 (each within the scatter of the next).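

In this assay, the aromatic carbon that is ortho to a large group and ortho to a fluoro group proves sensitive to substitution: fluoro in place of hydrogen there gives a 6.7-fold lower number from compound 2 to compound 3 (0.82 log units; beyond the scatter), whereas the earlier change of fluoro pattern between compound 1 and compound 2 stayed within the scatter. The 2,3,5,6-tetrafluorophenyl group also stands apart from the 2,3,4-trifluorophenyl group, with an 8.0-fold lower number from compound 1 to compound 3 (0.90 log units; beyond the scatter), so compound 3 is separated from both other compounds by steps beyond the scatter. Nothing available for these compounds explains the size of this step.

The compounds shown leave open whether this step is particular to fluoro, or whether chloro, methyl or methoxy on the same aromatic carbon would lower the number to a similar extent. They also leave open whether fluoro on the last aromatic carbon still bearing hydrogen, which would give a pentafluorophenyl group, would lower the number further, and whether the step would hold with a different group in place of the carboxylic acid on the shared core.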